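The source may report more compounds than this note shows. Statements on the series, on what has been measured and on what is new or still open speak of the compounds shown alone.

Of the compounds shown here, two of the shared core have numbers so far. In a functional assay (muscle tissue) with Cavia porcellus as the target (on this read-out lower numbers stand for an effect already at smaller amounts and higher numbers for an effect only at larger amounts of compound), compound 1 `COC(=O)C1=C(C)N=C(C)/C(=C(\O)OC)C1c1cccc(OC(C)=O)c1` gives 6030 nM, while compound 2 `COC(=O)C1=C(C)N=C(C)/C(=C(\O)OC)C1c1c(Cl)cccc1Cl` gives 1.91 nM, the lowest of the two values and separated from compound 1 by a gap well beyond the scatter. Compound 3 `COC(=O)C1=C(C)N=C(C)/C(=C(\O)OC)C1c1cccc(Cl)c1Cl` has not been measured. It differs from compound 2 by 2,3-dichlorophenyl in place of 2,6-dichlorophenyl on a saturated ring carbon. Among the compounds with values here, no measured pair shows this change, so the step from compound 2 is expected to be small, at most a modest rise in the number, as in a 2.1-fold higher number from compound 2 to compound 3 (0.32 log units; beyond the scatter). Compound 3 is therefore estimated at 4 nM, within a range of 1 nM to 20 nM.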

Compound 3, half-maximal effective concentration: 19.1 nM
Estimate against measurement, compound 3: 4.8-fold (0.68 log units) below, within the range that was stated.
By their numbers in this assay, from the lowest: compound 2; then compound 3; then compound 1.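

In this assay, the 2,3-dichlorophenyl in place of 2,6-dichlorophenyl on the saturated ring carbon gives a 10-fold higher number from compound 2 to compound 3 (1.00 log units; beyond the scatter). The same atoms are present in both groups, so the arrangement of the two chlorines alone registers on this read-out, which the earlier pair, differing in more than chlorine placement, could not show. No measurement at hand accounts for this step. Still open, from the compounds shown here alone, is whether 2,6-dimethoxyphenyl or 2,6-dimethylphenyl at this position would match compound 2, which gives 1.91 nM.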